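Swapping the urea aryl group: dichloro to trifluoromethyl

The source may hold more compounds than are shown below. What is called first, only, known or untested is meant among the compounds shown, and "the series" means these compounds.

Three pyrazole compounds sharing one core were tested in a functional assay on UACC-62 cells (Homo sapiens) for inhibition, read by sulforhodamine B assay, with a stated time of 48 h, tested at 10 uM; a lower number here means a stronger effect, a higher number a weaker effect of the compound at the concentration tested. Compound 1 `COc1cc(Cl)cc(-c2nn(-c3cccc(NC(=O)c4ccc(Cl)c(Cl)c4)c3)cc2-c2ccncc2)c1` gives 75.4%, while compound 2 `COc1cc(Cl)cc(-c2nn(-c3cccc(NC(=O)Nc4cc(C(F)(F)F)cc(C(F)(F)F)c4)c3)cc2-c2ccncc2)c1` gives -21.2% and compound 3 `COc1cc(Cl)cc(-c2nn(-c3cccc(NC(=O)Nc4ccc(Cl)c(Cl)c4)c3)cc2-c2ccncc2)c1` gives 4.38%, the second highest of the three numbers. Among the measured compounds shown here, the one measured step, a number 71 percentage points lower from compound 1 to compound 3 (beyond the scatter), shows that replacing an amide by a urea lowered the number sharply. Compound 4 `COc1cc(Cl)cc(-c2nn(-c3cccc(NC(=O)Nc4cccc(C(F)(F)F)c4)c3)cc2-c2ccncc2)c1` differs from compound 3 by 3-(trifluoromethyl)phenyl in place of 3,4-dichlorophenyl on an amide-type nitrogen. For the measured compounds named here, no measured step matches this change; compound 2 and compound 3 only show that a urea carrying two trifluoromethyl groups sits lower than one carrying two chlorines. For compound 4 a small downward step of a number 9.4 percentage points lower from compound 3 to compound 4 (within the scatter) is therefore expected, with the estimate for compound 4 in this assay being -5%, ranging from -30% to 25%.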

Compound 4, a percentage reported as activity, at one concentration (the size of the read-out at that concentration, not a potency): -11.5%
Estimate against measurement, compound 4: 6.5 percentage points above; the range from low to high includes it.
By their numbers in this assay, from the lowest: compounds 2 and 4 (each within the scatter of the next); then compound 3; then compound 1.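

In this assay the step at this amide-type nitrogen reads a number 15.9 percentage points lower from compound 3 to compound 4 (beyond the scatter), so 3-(trifluoromethyl)phenyl and 3,4-dichlorophenyl can be told apart here. A second trifluoromethyl group makes no clear difference, with a number 9.7 percentage points higher from compound 2 to compound 4 (within the scatter). Going from the amide with 3,4-dichlorophenyl to the urea with 3-(trifluoromethyl)phenyl gives a number 86.9 percentage points lower from compound 1 to compound 4 (beyond the scatter), a step that changes both the linker and the aryl group. Nothing available explains these differences. Going by these compounds, it remains open how a urea would behave with an amine or a carboxylic acid in place of trifluoromethyl on this aromatic ring.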